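Series notes: the step from compound 2 to compound 4

The source may hold more compounds than are shown below. What is called first, only, known or untested is meant among the compounds shown, and "the series" means these compounds.

Measured so far:
compound 1 `CNC(=O)c1cnc(C(=O)CCc2ccc(COc3ccccc3)cc2)o1` 3.6 nM
compound 2 `COC(=O)c1ccc(-c2cnc(C(=O)CCc3ccc(-c4ccccc4)cc3)o2)nc1` 2.2 nM
compound 3 `NC(=O)c1cccc(-c2cnc(C(O)CCc3ccc(-c4ccccc4)cc3)o2)n1` 20000 nM

In an assay for inhibition of Fatty-acid amide hydrolase 1 (Rattus norvegicus) (a higher number here means a weaker inhibitor, a lower number a stronger inhibitor), compound 2 gives 2.2 nM, the lowest of the three numbers. Compound 1, with 3.6 nM, lies within the scatter of it, so the two cannot be ranked against each other. Among the measured compounds shown here, compound 3, at 20000 nM, stands far higher, beyond the scatter; no single-point step to compound 3 is defined in this set, so only the bare values are compared.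

Compound 4 `N#Cc1cccc(-c2cnc(C(=O)CCc3ccc(-c4ccccc4)cc3)o2)n1` is not yet measured. It differs from compound 2 in one place: 6-cyanopyridin-2-yl in place of 5-(methoxycarbonyl)pyridin-2-yl on an aromatic carbon. The ketone chain and the biphenyl end of compound 2 are kept. With no measured step of this kind in the set, no change beyond the scatter is expected; a small shift in either direction would be unsurprising.

Compound 4 is estimated at 4 nM, with a likely range from 1 nM to 20 nM. This estimate implies a step of a 1.8-fold higher number from compound 2 to compound 4 (0.26 log units; within the scatter), expected to stay within the scatter.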

Compound 4, inhibition constant: 2.9 nM
The estimate for compound 4 lay 1.4-fold (0.14 log units) above the measured number; low and high end bracket the measured number.
By their numbers in this assay, from the lowest: compounds 2, 4 and 1 (each within the scatter of the next); then compound 3.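

At the aromatic carbon next to the ring oxygen, the step to 6-cyanopyridin-2-yl in place of 5-(methoxycarbonyl)pyridin-2-yl is a 1.3-fold higher number from compound 2 to compound 4 (0.12 log units; within the scatter) in this assay and so gives no measurable difference. This position therefore carries either substituted pyridinyl group with the ketone chain and biphenyl end kept, although the entering group has a nitrile where the leaving group has a methyl ester, and the two groups place their substituents differently on the ring. No measurement is available to explain why the two groups read alike.

Since the substituent and its place on the ring differ together, this single step cannot separate their contributions. Open, from the compounds shown here alone, is how an unsubstituted pyridin-2-yl, or a pyridin-2-yl bearing a carboxylic acid or an amine, would read at this position.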